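Adding a Chlorine to a Pyridine Ether

The compounds below may be only part of what the source reports. "The series", "measured", "known", "first", "only" and "open" are said of these compounds alone.

Measured compounds:
- compound 1, `Cn1c(COc2cccc(C(=O)O)c2)nc2ccc(Oc3ccc4c(c3)CCC4)nc21`: 31.5 10^-6 cm/s
- compound 2, `Cn1c(COc2cccc(C(=O)O)c2)nc2ccc(Oc3ccccn3)cc21`: 2.2 10^-6 cm/s

The read-out here is an ADME assay for permeability, using PAMPA, with a stated time of 4 h; a higher number here means that the compound crosses the layer faster, a lower number that the compound crosses the layer more slowly. In this assay compound 1 gives 31.5 10^-6 cm/s, while compound 2 gives 2.2 10^-6 cm/s, the lower of the two numbers, and the gap between them is beyond the scatter. Compound 1 and compound 2 differ in more than one place, so nothing more can be drawn from that comparison than the two values themselves.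

Compound 3, `Cn1c(COc2cccc(C(=O)O)c2)nc2ccc(Oc3ccc(Cl)cn3)cc21`, has not yet been measured. It differs from compound 2 by chloro in place of hydrogen on an aromatic carbon. Nothing in the two measured compounds tells how such a change plays out in this assay, so the expectation rests on the structural change alone. A step upward is expected, but a small one, and it may well stay within the scatter. The step of a 1.8-fold higher number from compound 2 to compound 3 (0.26 log units; within the scatter) is an estimate only. Compound 3 is expected to give about 4 10^-6 cm/s, with a likely range from 1.5 10^-6 cm/s to 10 10^-6 cm/s.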

Compound 3, apparent permeability: 16.2 10^-6 cm/s
Estimate against measurement, compound 3: 4.1-fold (0.61 log units) below; the whole stated range lies below it.
By their numbers in this assay, from the lowest: compound 2; then compounds 3 and 1 (each within the scatter of the next).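

Among these compounds, this pair is the first here that differs in one place, so a change in this assay can now be tied to a single spot: chloro in place of hydrogen, on the aromatic carbon two atoms from the ring nitrogen, gives a 7.4-fold higher number from compound 2 to compound 3 (0.87 log units; beyond the scatter). One heavy atom, adding no ring, no charge and no hydrogen-bond donors or acceptors, is thus enough to move the number beyond the scatter at this position. No measurement here gives the reason for this step.

From the compounds shown here alone, it remains open whether the step is specific to chloro, or whether a fluoro, methyl or methoxy group at the same place would give a similar one. Also open, going by these compounds, is whether chloro on another carbon of this ring would have a comparable effect.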